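From Bromo to Chloro in a Small Cytotoxic Series

This account rests on a few compounds, and the source may have more. Where it says the series, first, only, none or still open, it means among the compounds named here.

In a functional assay on MCF7 cells (Homo sapiens) for cytotoxicity, read by MTT assay, with a stated time of 72 h (a higher number here means a weaker inhibitor, a lower number a stronger inhibitor), compound 1 `CNC(=O)c1cc(Oc2ccc(C(=O)/C=C/c3ccccc3)cc2)ccn1` gives 5960 nM and compound 2 `CNC(=O)c1cc(Oc2ccc(C(=O)/C=C/c3ccc(F)cc3)cc2)ccn1` gives 28500 nM. Compound 3 `CNC(=O)c1cc(Oc2ccc(/C=C/C(=O)c3ccc(Br)cc3)cc2)ccn1` gives 7100 nM, the second highest of the three numbers. It lies within the scatter of the number for compound 1 and well under the number for compound 2.

Compound 4 `CNC(=O)c1cc(Oc2ccc(/C=C/C(=O)c3ccc(Cl)cc3)cc2)ccn1` has not yet been measured. It differs from compound 3 by chloro in place of bromo on an aromatic carbon, para to a large group.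

Going by the values given here, only one measured step involves a halogen, a 4.8-fold higher number from compound 1 to compound 2 (0.68 log units; beyond the scatter), a modest change beyond the scatter with fluoro in place of hydrogen on an aromatic carbon. It is an indirect guide, since it starts from hydrogen rather than bromo, and compound 1 and compound 2 carry their carbonyl at the other end of the chain. Among the compounds with values here, no measured pair compares chloro with bromo directly, so a step of that size is not carried over. The change expected in this assay is small and stays within the scatter, with the estimate being a 1.2-fold higher number from compound 3 to compound 4 (0.08 log units; within the scatter). For compound 4 the estimated value is 8500 nM, with an expected range from 3500 nM to 20000 nM.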

Compound 4, half-maximal inhibitory concentration: 17500 nM
The estimate for compound 4 lay 2.1-fold (0.31 log units) below the measured number; measured number inside the range.
By their numbers in this assay, from the lowest: compounds 1 and 3 (each within the scatter of the next); then compounds 4 and 2 (each within the scatter of the next).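

In this assay, exchanging bromo for chloro on this aromatic carbon, para to a large group, gives a 2.5-fold higher number from compound 3 to compound 4 (0.39 log units; beyond the scatter), a modest step but one beyond the scatter. Going by these compounds alone, the earlier compounds offered only a step from hydrogen to fluoro, with the carbonyl at the other end of the chain, so this is the first pair in which one halogen replaces another with the rest of the structure unchanged, and it shows that the number in this assay is sensitive to which halogen sits here. No measurement at hand bears on the cause of this step.

It remains open whether the same exchange would move the number in the same direction with the carbonyl at the other end of the chain, since the compounds shown include no chloro or bromo partner of that arrangement. They also leave unknown how fluoro, hydrogen, or a different kind of group such as an amine, a methoxy group or a carboxylic acid would read in this same place on the chain shared by compound 3 and compound 4.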